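A few compounds are considered here, and "the series" means these few. Any claim that something is new, unique, unknown or untested is made for them only; others in the source may bear on it.

Measured so far:
compound 1 `N/C(=N/NC(CC(=O)c1ccc(-n2ccnc2)cc1)c1ccccc1[N+](=O)[O-])c1ccccn1`: 48000 nM
compound 2 `N/C(=N/NC(CC(=O)c1ccc(-n2ccnc2)cc1)c1cccc(Cl)c1)c1ccccn1`: 68600 nM

In an ADME assay on Vero cells (Chlorocebus sabaeus) for cytotoxicity, read by MTT assay, with a stated time of 72 h (on this read-out lower numbers stand for higher toxicity in this test and higher numbers for lower toxicity in this test), compound 2 gives 68600 nM, the highest of the two numbers, with compound 1 nearest at 48000 nM; the step of a 1.4-fold higher number from compound 1 to compound 2 (0.16 log units; within the scatter) lies within the scatter. Compound 3 `N/C(=N/NC(CC(=O)c1ccc(-n2ccnc2)cc1)c1ccc([N+](=O)[O-])cc1)c1ccccn1` differs from compound 2 by 4-nitrophenyl in place of 3-chlorophenyl on a saturated chain carbon bound to an amine nitrogen and a saturated chain carbon. For the measured compounds named here, only one measured step bears on this place, the change from a 2-nitrophenyl to a 3-chlorophenyl, and it stayed within the scatter, so no shift beyond the scatter in this assay is expected. Compound 3 is estimated at 55000 nM, between 25000 nM and 120000 nM, a step of a 1.2-fold lower number from compound 2 to compound 3 (0.10 log units; within the scatter).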

Compound 3, half-maximal cytotoxic concentration: 23100 nM
Estimate against measurement, compound 3: 2.4-fold (0.38 log units) above, outside the stated range (below it).
By their numbers in this assay, from the lowest: compound 3; then compounds 1 and 2 (each within the scatter of the next).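

Unlike the earlier exchange of 2-nitrophenyl for 3-chlorophenyl, which stayed within the scatter, 4-nitrophenyl at this place gives a 3.0-fold lower number from compound 2 to compound 3 (0.47 log units; beyond the scatter) and a 2.1-fold lower number from compound 1 to compound 3 (0.32 log units; beyond the scatter) in this assay and so shows that this position can shift the number modestly beyond the scatter. The 2-nitrophenyl and 4-nitrophenyl groups do not read alike here, so the nitro group alone does not set the number. Nothing measured here accounts for this shift. From the compounds shown here alone, how 4-chlorophenyl, 3-nitrophenyl, or unsubstituted phenyl would read at this place remains open.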